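This account rests on a few compounds, and the source may have more. Where it says the series, first, only, none or still open, it means among the compounds named here.

Compound 1 `Fc1ccc(Cc2ccc3c(NCCCNCc4ccco4)ccnc3c2)c(Cl)c1` gives 23 10^-6 cm/s in an ADME assay for permeability, using PAMPA, with a stated time of 30 min, at pH 7.4; on this read-out lower numbers stand for lower permeability and higher numbers for higher permeability. Compound 2 `c1coc(CNCCCNc2ccnc3cc(-c4cccc5ccccc45)ccc23)c1` carries naphthalen-1-yl in place of 2-chloro-4-fluorobenzyl on an aromatic carbon and gives 237 10^-6 cm/s in this assay, a step of a 10-fold higher number from compound 1 to compound 2 (1.01 log units; beyond the scatter). Compound 3 `COc1cccc(CNCCCNc2ccnc3cc(Cc4ccc(F)cc4Cl)ccc23)c1O` differs from compound 1 by 2-hydroxy-3-methoxyphenyl in place of furan-2-yl on a saturated chain carbon bound to an amine nitrogen. In this assay compound 3 gives 23 10^-6 cm/s, a step of no change at the digits printed from compound 1 to compound 3 (within the scatter). Compound 4 `COc1cccc(CNCCCNc2ccnc3cc(-c4cccc5ccccc45)ccc23)c1O` is not yet measured in this assay; it differs from compound 3 by naphthalen-1-yl in place of 2-chloro-4-fluorobenzyl on an aromatic carbon, the same change that separates compound 2 from compound 1, and the place is described in the same words in both pairs. The two cores differ by 2-hydroxy-3-methoxyphenyl in place of furan-2-yl on a saturated chain carbon bound to an amine nitrogen. Because the earlier step of a 10-fold higher number from compound 1 to compound 2 (1.01 log units; beyond the scatter) was large, an increase of about a 9.6-fold higher number from compound 3 to compound 4 (0.98 log units; beyond the scatter) is expected from compound 3 to compound 4 in this assay. Compound 4 is therefore estimated at 220 10^-6 cm/s in this assay, between 90 10^-6 cm/s and 450 10^-6 cm/s.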

Compound 4, apparent permeability: 237 10^-6 cm/s
Compound 4: the middle estimate sits 1.1-fold (0.03 log units) below what was measured; measured number inside the range.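

Putting naphthalen-1-yl in place of 2-chloro-4-fluorobenzyl gives a 10-fold higher number from compound 3 to compound 4 (1.01 log units; beyond the scatter) in this assay, and the step carries over from one core to the other: the same change on two cores in this assay, a 10-fold higher number (1.01 log units; beyond the scatter) from compound 1 to compound 2 and a 10-fold higher number (1.01 log units; beyond the scatter) from compound 3 to compound 4, 1.0-fold (0.00 log units) apart, within the scatter of two such steps
Putting 2-hydroxy-3-methoxyphenyl in place of furan-2-yl gives no change at the digits printed from compound 2 to compound 4 (within the scatter), matching the result with 2-chloro-4-fluorobenzyl on the aromatic carbon: the same change on two cores in this assay, no change at the digits printed (within the scatter) from compound 1 to compound 3 and no change at the digits printed (within the scatter) from compound 2 to compound 4, 1.0-fold (0.00 log units) apart, within the scatter of two such steps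
This is a single pair of cores in one assay, so it supports transfer of the change between these two cores only and does not show why the step arises or whether it holds on other cores.

Open, going by these compounds, is whether the step persists with a carboxylic acid on the aromatic ring in place of the 2-hydroxy-3-methoxyphenyl group, or with a longer chain in the linker. Also open, on these data alone, is how a plain phenyl group compares with naphthalen-1-yl on the aromatic carbon.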